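The source may hold more compounds than are shown below. What is called first, only, known or untested is meant among the compounds shown, and "the series" means these compounds.

Measured so far:
compound 1, `NC(=O)c1c(NC(=O)c2ccccc2Cl)sc2c1CCN(C(=S)Nc1cc(C(F)(F)F)cc(C(F)(F)F)c1)C2`: 48900 nM
compound 2, `NC(=O)c1c(NC(=O)c2ccccc2I)sc2c1CCN(C(=S)Nc1ccccc1Cl)C2`: > 50000 nM

In a functional assay on HeLa cells (Homo sapiens) for antiproliferative activity, with a stated time of 24 h (a lower number here means a stronger inhibitor, a higher number a weaker inhibitor), compound 1 gives 48900 nM. For compound 2 only a limit is reported, > 50000 nM, which is the limit of > 50000 nM in this assay, at which 1 of the 2 values shown sits; compound 2 therefore stands at the upper edge of this assay, with no number of its own. The two compounds are not a single-change pair, so their values show only that both sit at the weak end of this assay.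

Compound 3, `NC(=O)c1c(NC(=O)c2ccncn2)sc2c1CCN(C(=S)Nc1ccccc1Cl)C2`, differs from compound 2 in one place: pyrimidin-4-yl in place of 2-iodophenyl on a carbonyl carbon. Among the measured compounds shown here, no measured step in this assay covers a change of this kind, so there is nothing to set the size or direction of the step; the expectation is for no step beyond the scatter, a number no higher from compound 2 to compound 3 (the limit leaves the size open). Compound 3 is accordingly expected to give about 50000 nM in this assay, within a range from 20000 nM to 120000 nM, with a real chance that only a limit is reported again.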

Compound 3, half-maximal inhibitory concentration: > 50000 nM
Compound 3: only a limit was reported; the forecaster's own chance of this, stated with the estimate: 60%; the middle value lies on the limit itself.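

Compound 2 and compound 3 each carry only a limit in this assay, so no step can be read between them: the limit of > 50000 nM in this assay, at which 2 of the 3 values shown sit.

The compounds shown leave open whether pyrimidin-4-yl in place of 2-iodophenyl on a carbonyl carbon changes the value in this assay at all.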